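A few compounds are considered here, and "the series" means these few. Any claim that something is new, unique, unknown or untested is made for them only; others in the source may bear on it.

Compound 1: `Cc1ccc(S(=O)(=O)n2cc(CN(Cc3cn(Cc4ccc(F)cc4)nn3)S(C)(=O)=O)c3ccccc32)cc1`, -19.5%. Compound 2: `Cc1ccc(S(=O)(=O)n2cc(CN(Cc3ccccc3)Cc3cccc(F)c3F)c3ccccc32)cc1`, -13.1%.

Of the compounds shown here, two sharing the same core have been measured in a functional assay on 3T3-L1 cells (Mus musculus) for inhibition, with a stated time of 20 min, tested at 20 uM; on this read-out higher numbers stand for more inhibition at the one concentration tested (going by the name of the read-out) and lower numbers for less inhibition. Among the compounds with values here, compound 2 gives -13.1%, and compound 1, the only other number, lies within the scatter of that value, so the two cannot be told apart. Compound 3, `Cc1ccc(S(=O)(=O)n2cc(CN(Cc3cccc(F)c3F)S(C)(=O)=O)c3ccccc32)cc1`, has not yet been measured. It differs from compound 2 in one place: methylsulfonyl in place of benzyl on an amine nitrogen. Within the data shown here, with no comparable step on record, no change beyond the scatter is expected in this assay from compound 2 to compound 3, the expected step being a number 1.9 percentage points lower from compound 2 to compound 3 (within the scatter). Compound 3 is therefore estimated at -15%, between -35% and 5%.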

Compound 3, a percentage reported as inhibition, at one concentration (the size of the read-out at that concentration, not a potency): -3.3%
The estimate for compound 3 lay 11.7 percentage points below the measured number; low and high end bracket the measured number.
By their numbers in this assay, from the lowest: compounds 1, 2 and 3 (each within the scatter of the next, the first and the last beyond it).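

In this assay, methylsulfonyl in place of benzyl on an amine nitrogen gives a number 9.8 percentage points higher from compound 2 to compound 3 (within the scatter), so this single exchange, which removes an aromatic ring and adds two hydrogen-bond acceptors, stays within the usual scatter. At this position, the benzyl is therefore not shown to be needed for the read-out. No supporting measurement bears on this result. As far as these compounds go, it remains open whether a carboxylic acid, an acetyl group or a longer chain on this amine nitrogen would give a number beyond the scatter.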